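The source may hold more compounds than are shown below. What is called first, only, known or untested is meant among the compounds shown, and "the series" means these compounds.

Compound 1 `O=C(CCCCC(S)CCS)Nc1ccccc1`: 5.49%
Compound 2 `O=C(CCCCC(S)CCS)Nc1cccc(C(F)(F)F)c1`: 8.86%

In a functional assay on HO8910 cells (Homo sapiens) for inhibition, read by MTT assay, with a stated time of 24 h, tested at 10 ug/mL (on this read-out lower numbers stand for less inhibition of growth and higher numbers for more inhibition of growth at the one concentration tested), compound 1 gives 5.49%, so little growth is inhibited at the one concentration tested. Among the measured compounds shown here, its only measured neighbour, compound 2, lies within the scatter of it.

Compound 3 `O=C(CCCCC(S)CCS)Nc1ccc(OC(F)(F)F)cc1` has not been measured yet. It is the core of compound 1 with one change: trifluoromethoxy in place of hydrogen on an aromatic carbon. In words, trifluoromethoxy stands in place of hydrogen on an aromatic carbon, para to a large group.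

For the measured compounds named here, the one measured step that bears on this is the related change in compound 2, trifluoromethyl in place of hydrogen on an aromatic carbon: a number 3.4 percentage points higher from compound 1 to compound 2 (within the scatter). It is a different group, and it is a single step, so it is only a rough guide. No shift beyond the scatter is therefore expected in this assay. The expected step is small: a number 2.5 percentage points higher from compound 1 to compound 3 (within the scatter). For compound 3 the estimated value is 8%, with an expected range from 1% to 18%.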

Compound 3, percent growth inhibition at one concentration: 6.11%
Compound 3: middle estimate off by 1.9 percentage points, on the high side; the measured number falls inside the stated range.
By their numbers in this assay, from the lowest: compounds 1, 3 and 2 (each within the scatter of the next).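

In this assay, trifluoromethoxy on an aromatic carbon, para to a large group, gives a number 0.6 percentage points higher from compound 1 to compound 3 (within the scatter). This adds a second substituted compound to the comparison, and at this position a group of 5 heavy atoms with 1 hydrogen-bond acceptor still leaves growth inhibition small at the one concentration tested, with no shift from the core of compound 1 that can be told from scatter. No measurement is available that could explain this result.

The compounds shown leave open whether a different kind of group at this position, such as an amine or a carboxylic acid, would move the number beyond the scatter. They also leave open whether changing the core itself, for example by giving it a longer chain, would do so.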